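The source may report more compounds than this note shows. Statements on the series, on what has been measured and on what is new or still open speak of the compounds shown alone.

Compound 1 `C/C(=N\OCCSc1nnc(C)s1)c1ccc(Sc2cc(F)cc(C3CCOCC3)c2)cc1`: 230 nM in a functional assay (blood) for inhibition, with Homo sapiens as the target; a higher number here means a weaker inhibitor, a lower number a stronger inhibitor.
Compound 2 `C/C(=N\OCCF)c1ccc(Sc2cc(F)cc(C3CCOCC3)c2)cc1`: 40 nM.
Compound 3 `C/C(=N\OC(=O)C(C)(C)C)c1ccc(Sc2cc(F)cc(C3CCOCC3)c2)cc1`: 40 nM.

Compound 3 stands level with compound 2 at the digits shown (no change at the digits printed from compound 2 to compound 3 (within the scatter)), and the two together give the lowest numbers of the three, while compound 1 gives the highest (a 5.8-fold lower number from compound 1 to compound 3 (0.76 log units; beyond the scatter)). Compound 4 `COC(=O)c1cc(CO/N=C(\C)c2ccc(Sc3cc(F)cc(C4CCOCC4)c3)cc2)on1` differs from compound 3 in one place: (3-(methoxycarbonyl)-1,2-oxazol-5-yl)methyl in place of (tert-butyl)carbonyl on an oxygen. Going by the values given here, the steps that bear on this are a 5.8-fold lower number from compound 1 to compound 3 (0.76 log units; beyond the scatter) and a 5.8-fold lower number from compound 1 to compound 2 (0.76 log units; beyond the scatter), both of which moved the number down when a chain bearing a five-membered aromatic ring with hetero atoms left that oxygen. Because compound 3 gives 40 nM and the step of a 5.8-fold lower number from compound 1 to compound 3 (0.76 log units; beyond the scatter) moved the number down when such a ring left that oxygen, while the change to compound 4 again places such a ring on that oxygen, a modest rise is expected: a 2.5-fold higher number from compound 3 to compound 4 (0.40 log units; beyond the scatter). Compound 4 is therefore estimated at 100 nM, with a range from 40 nM to 300 nM.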

Compound 4, half-maximal inhibitory concentration: 100 nM
Compound 4: middle estimate and measured number agree at the digits printed; the range from low to high includes it.
By their numbers in this assay, from the lowest: compounds 2 and 3 (each within the scatter of the next); then compound 4; then compound 1.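

In this assay the (3-(methoxycarbonyl)-1,2-oxazol-5-yl)methyl group on this oxygen gives a 2.5-fold higher number from compound 3 to compound 4 (0.40 log units; beyond the scatter) and a 2.5-fold higher number from compound 2 to compound 4 (0.40 log units; beyond the scatter) but also a 2.3-fold lower number from compound 1 to compound 4 (0.36 log units; beyond the scatter) and so places compound 4 between the others. A five-membered aromatic ring on this oxygen's chain therefore does not by itself bring the number back to that of compound 1. Nothing available here explains these steps. From the compounds shown here alone, whether the methoxycarbonyl matters stays open, as does what a carboxylic acid in its place, or a longer chain between ring and oxygen, would give.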